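Benzyl for Cyclopentyl on the Double-bonded Nitrogen

The source may report more compounds than this note shows. Statements on the series, on what has been measured and on what is new or still open speak of the compounds shown alone.

Measured compounds:
Compound 1, `CC(C)/N=C(\S)OC[C@H]1OC(n2cnc3c(NC4CCOC4)ncnc32)[C@H](O)[C@@H]1O`, 36 nM in an assay on DDT1 cells (Cricetulus griseus) for binding affinity to adenosine receptor A1 (Homo sapiens), read by radioligand binding; on this read-out higher numbers stand for weaker inhibition and lower numbers for stronger inhibition.
Compound 2, `O[C@@H]1[C@@H](CO/C(S)=N/C2CCCC2)OC(n2cnc3c(NC4CCOC4)ncnc32)[C@@H]1O`, 72 nM in this assay.

Among the measured compounds shown here, compound 2 gives the highest of the two numbers in this assay, and its only neighbour is compound 1, which sits a short way off: a 2.0-fold higher number from compound 1 to compound 2 (0.30 log units; within the scatter). So the two measured compounds are not separated beyond the scatter in this assay.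

Compound 3, `O[C@@H]1[C@@H](CO/C(S)=N/Cc2ccccc2)OC(n2cnc3c(NC4CCOC4)ncnc32)[C@@H]1O`, has not yet been measured in this assay. It differs from compound 2 in one place: benzyl in place of cyclopentyl on a double-bonded nitrogen.

For the measured compounds named here, the single measured step that bears on this change is the one at the same nitrogen, a 2.0-fold higher number from compound 1 to compound 2 (0.30 log units; within the scatter), which swapped one carbon group for another and stayed within the scatter. On that basis the account expects the move to benzyl to give no step beyond the scatter in this assay, with a modest lean toward a higher number because compound 2 already sits at 72 nM.

Compound 3 is therefore estimated at 90 nM in this assay, in a range of 30 nM to 270 nM, which would mean an expected step of a 1.3-fold higher number from compound 2 to compound 3 (0.10 log units; within the scatter).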

Compound 3, inhibition constant: 12 nM
For compound 3 the middle estimate is 7.5-fold (0.88 log units) above the measured one; measured number outside the range, below it.
By their numbers in this assay, from the lowest: compound 3; then compounds 1 and 2 (each within the scatter of the next).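

At the double-bonded nitrogen, the earlier pair showed only that isopropyl and cyclopentyl could not be told apart in this assay. The new result shows that this position does respond to the group it carries, with a 6.0-fold lower number from compound 2 to compound 3 (0.78 log units; beyond the scatter) for benzyl in place of cyclopentyl, and the change also holds against the other carbon group, with a 3.0-fold lower number from compound 1 to compound 3 (0.48 log units; beyond the scatter) for benzyl in place of isopropyl. Among the compounds shown here, both steps lie beyond the scatter and run the same way, so benzyl, the only one of the three groups with an aromatic ring, gives the lowest number of the series, though no evidence is at hand on what lies behind this.

The compounds shown leave open whether the aromatic ring itself is what counts, a question that a cyclohexylmethyl group on the same nitrogen would bear on. They also leave open how far the lower number would carry to a phenyl group set directly on that nitrogen, to a longer chain such as phenethyl, or to a pyridylmethyl group.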